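Swapping the Alkynyl Chain for a Hydroxy Chain

This account rests on a few compounds, and the source may have more. Where it says the series, first, only, none or still open, it means among the compounds named here.

Compound 1 `CCN(CC)CCNC(=O)c1ccc(C(CC)(CC)c2ccc(OCC(=O)C(C)(C)C)c(C)c2)n1CC` gives 91 nM in an assay on HL-60 cells for agonist activity at vitamin D3 receptor (Homo sapiens), read by microscopy, with a stated time of 96 h; a lower number here means that less compound is needed, a higher number that more compound is needed for the effect.
Compound 2 `CCn1c(C(=O)NCCCN(C)C)ccc1C(CC)(CC)c1ccc(OCC(=O)C(C)(C)C)c(C)c1` gives 96 nM in this assay.
Compound 3 `C#CCCOC(=O)c1ccc(C(CC)(CC)c2ccc(OCC(=O)C(C)(C)C)c(C)c2)n1CC` gives 28800 nM in this assay.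

Compound 3 has the highest number of the three: a 300-fold higher number from compound 2 to compound 3 (2.48 log units; beyond the scatter), and a 320-fold higher number from compound 1 to compound 3 (2.50 log units; beyond the scatter). Compound 4 `CCn1c(C(=O)OC(C)CCO)ccc1C(CC)(CC)c1ccc(OCC(=O)C(C)(C)C)c(C)c1` differs from compound 3 by 3-hydroxy-1-methylpropyl in place of but-3-yn-1-yl on an oxygen next to a carbonyl group. The two measured steps each exchanged an amine-bearing amide chain for the oxygen-linked chain of compound 3, and both were large. Among the measured compounds shown here, compound 4 keeps that oxygen-linked arrangement and changes only the chain, so no measured step bears directly on it. The expected step is therefore small, a 1.3-fold lower number from compound 3 to compound 4 (0.12 log units; within the scatter), within the scatter of repeated measurements. Compound 4 is estimated at 22000 nM in this assay, with a range from 6000 nM to 80000 nM.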

Compound 4, half-maximal effective concentration: 380 nM
For compound 4 the middle estimate is 58-fold (1.76 log units) above the measured one; measured number outside the range, below it.
By their numbers in this assay, from the lowest: compounds 1 and 2 (each within the scatter of the next); then compound 4; then compound 3.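

In this assay, the chain on this oxygen turns out to matter a great deal: 3-hydroxy-1-methylpropyl in place of but-3-yn-1-yl gives a 76-fold lower number from compound 3 to compound 4 (1.88 log units; beyond the scatter). The oxygen-linked arrangement therefore need not cost most of the earlier loss, although a 4.0-fold higher number from compound 2 to compound 4 (0.60 log units; beyond the scatter) and a 4.2-fold higher number from compound 1 to compound 4 (0.62 log units; beyond the scatter) leave the amine-bearing amide chains with the lower numbers. No measured evidence here explains the change. From the compounds shown here alone, whether the hydroxy group or the methyl branch drives the step remains open; a 3-hydroxypropyl chain and a plain butyl chain on this oxygen would help separate them.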